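Swapping isopropyl for chloro on a macrophage tolerability series

The compounds below may be only part of what the source reports. "The series", "measured", "known", "first", "only" and "open" are said of these compounds alone.

The account concerns compound 3 `CC(C)c1ccc(-c2cc(-c3ccc(OCc4cn(Cc5ccccc5)nn4)cc3O)nc(N)n2)cc1` and its counterpart compound 4 `Nc1nc(-c2ccc(Cl)cc2)cc(-c2ccc(OCc3cn(Cc4ccccc4)nn3)cc2O)n1`, which has not yet been tested. In an ADME assay on cells (Macrophage) for cytotoxicity, read by resazurin assay, with a stated time of 48 h (a lower number here means that less compound is tolerated, a higher number that more compound is tolerated), compound 3 reaches only a limit, > 100000 nM, as the evidence notes (the limit of > 100000 nM in this assay, at which 1 of the 3 values shown sits). Two measured neighbours set the scene: compound 2 `COc1ccc(-c2cc(-c3ccc(OCc4cn(Cc5ccccc5)nn4)cc3O)nc(N)n2)cc1` gives 42700 nM, and the step of an at least 2.3-fold higher number from compound 2 to compound 3 (0.36 log units; beyond the scatter) shows that the isopropyl analogue is tolerated better. Compound 1 `CCCCCCn1cc(COc2ccc(-c3cc(-c4ccc(Cl)cc4)nc(N)n3)c(O)c2)nn1` gives 30300 nM in this assay. The change is chloro in place of isopropyl on an aromatic carbon. Since compound 1 carries the same chlorophenyl and sits at 30300 nM, the chloro analogue is expected to be tolerated less well than compound 3, giving the estimated step of an at least 2.5-fold lower number from compound 3 to compound 4 (0.39 log units; beyond the scatter). Compound 4 is therefore estimated at 40000 nM in this assay, within 15000 nM to 100000 nM.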

Compound 4, half-maximal cytotoxic concentration: 66600 nM
Beside the measured number, compound 4's estimate is 1.7-fold (0.22 log units) below it; the measured number falls inside the stated range.
By their numbers in this assay, from the lowest: compounds 1, 2 and 4 (each within the scatter of the next, the first and the last beyond it). At a limit, above all of these: compound 3.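

Chloro in place of methoxy gives a 1.6-fold higher number from compound 2 to compound 4 (0.19 log units; within the scatter) in this assay, so the two groups are not told apart at this position. Chloro in place of isopropyl gives an at least 1.5-fold lower number from compound 3 to compound 4 (0.17 log units; that floor lies within the scatter), a floor set by a limit, so the true size of this change remains unknown. With the 4-chlorophenyl held fixed, phenyl in place of pentyl on a saturated chain carbon bound to an aromatic nitrogen gives a 2.2-fold higher number from compound 1 to compound 4 (0.34 log units; beyond the scatter), a modest step. As far as these compounds go, how an amine or a carboxylic acid would read at this position stays open.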